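Demethylation and Vero cell cytotoxicity in a quinone series

This account rests on a few compounds, and the source may have more. Where it says the series, first, only, none or still open, it means among the compounds named here.

Measured compounds:
compound 1 `COC1=C(CC(C)(C)CNC(=O)c2ccccc2OC)C(=O)c2ccccc2C1=O` — 27300 nM
compound 2 `COC1=C(CC(C)(C)CNC(=O)c2ccc3ccccc3c2OC)C(=O)c2ccccc2C1=O` — 60600 nM
compound 3 `COc1ccccc1C(=O)NCC(C)(C)CC1=C(O)C(=O)c2ccccc2C1=O` — 31200 nM

All three were read in an ADME assay on Vero cells (Chlorocebus sabaeus) for cytotoxicity, read by fluorescence, with a stated time of 4 days; on this read-out higher numbers stand for weaker inhibition and lower numbers for stronger inhibition. Compound 1 gives 27300 nM, compound 2 gives 60600 nM, and compound 3 gives 31200 nM. Compound 3 differs from compound 1 by hydrogen in place of methyl on an oxygen on an unsaturated carbon, and this step is a 1.1-fold higher number from compound 1 to compound 3 (0.06 log units; within the scatter). The difference between the cores of compound 1 and compound 2 is not broken down here. Compound 4 `COc1c(C(=O)NCC(C)(C)CC2=C(O)C(=O)c3ccccc3C2=O)ccc2ccccc12` is not yet measured; it differs from compound 2 by hydrogen in place of methyl on an oxygen on an unsaturated carbon, the same change as that from compound 1 to compound 3. Because a 1.1-fold higher number from compound 1 to compound 3 (0.06 log units; within the scatter) was within the scatter, the step from compound 2 to compound 4 is expected to be small as well, estimated as a 1.1-fold higher number from compound 2 to compound 4 (0.04 log units; within the scatter). For compound 4 in this assay the estimate is 67000 nM, expected between 30000 nM and 140000 nM.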

Compound 4, half-maximal inhibitory concentration: 47300 nM
For compound 4 the middle estimate is 1.4-fold (0.15 log units) above the measured one; the measured number falls inside the stated range.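

In this assay, the change from methoxy to hydroxy gives a 1.3-fold lower number from compound 2 to compound 4 (0.11 log units; within the scatter), so on this second core the step again stays within the scatter. Set beside the earlier step, the two agree: the same change on two cores in this assay, a 1.1-fold higher number (0.06 log units; within the scatter) from compound 1 to compound 3 and a 1.3-fold lower number (0.11 log units; within the scatter) from compound 2 to compound 4, 1.5-fold (0.17 log units) apart, within the scatter of two such steps. Among the compounds shown here, this shows that the change carried from one core to the other without a step beyond the scatter on either, but with only two pairs it does not show that this would hold on any further core, and neither step gives the change a direction.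

The compounds shown leave open what a longer chain in place of the methyl on that oxygen would do. On these data alone, an amine in place of the methoxy also remains open.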